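A few compounds are considered here, and "the series" means these few. Any claim that something is new, unique, unknown or untested is made for them only; others in the source may bear on it.

Measured in an ADME assay on HEK293 cells (Homo sapiens) for cytotoxicity, read by ATP content, with a stated time of 6 h; on this read-out higher numbers stand for lower toxicity in this test and lower numbers for higher toxicity in this test:
Compound 1 `CCCCNc1nc(N)nc2ccn(Cc3cn4ccccc4n3)c12`: > 24000 nM
Compound 2 `CCCCNc1nc(N)nc2ccn(Cc3ccncc3)c12`: > 24000 nM
Compound 3 `CC(Nc1nc(N)nc2ccn(Cc3ccccn3)c12)c1ccccn1`: > 24000 nM

Compound 3 stands at > 24000 nM, which is a limit of the assay and not a number. The other two entries are of the same kind, so the set reads as the limit of > 24000 nM in this assay, at which 3 of the 3 values shown sit. Among the compounds with values here, no compound in it can be ranked against another.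

Compound 4 `Nc1nc(NCc2ccon2)c2c(ccn2Cc2ccccn2)n1` differs from compound 3 in one place, on a nitrogen on an aromatic ring: (1,2-oxazol-3-yl)methyl in place of 1-(pyridin-2-yl)ethyl on a nitrogen on an aromatic ring. Here (1,2-oxazol-3-yl)methyl stands in place of 1-(pyridin-2-yl)ethyl. Within the data shown here, no measured pair shows this change on its own.

In this assay, no step beyond the scatter is expected in either direction, because compound 3 gives > 24000 nM, a limit. The estimated change, a number no higher from compound 3 to compound 4 (the limit leaves the size open), is correspondingly expected to be small. For compound 4 the estimated half-maximal cytotoxic concentration is 24000 nM, with an expected range of 14000 nM to 40000 nM.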

Compound 4, half-maximal cytotoxic concentration: > 24000 nM
Compound 4: only a limit was reported; the forecaster's own chance of this, stated with the estimate: 85%; the middle value sits exactly at the limit.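

In this assay compound 4 gives > 24000 nM, a limit of the assay and not a number. Within the data shown here, compound 3 also sits at a limit, so no step between compound 3 and compound 4 can be read. The compounds shown leave open how any of them ranks against another in this assay: the limit of > 24000 nM in this assay, at which 4 of the 4 values shown sit.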